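Aryl replacement on the shared core: compound 2 to compound 4

The compounds below may be only part of what the source reports. "The series", "measured", "known", "first", "only" and "open" are said of these compounds alone.

Compound 1 `COc1cc(-c2cc3nccc(-c4c[nH]c5ccccc45)n3n2)cc(OC)c1OC` in a functional assay on HeLa cells (Homo sapiens) for inhibition, read by CCK-8 assay, with a stated time of 48 h (on this read-out lower numbers stand for stronger inhibition and higher numbers for weaker inhibition), reports only a limit of the assay, > 10000 nM.
Compound 2 `COc1cc(-c2ccnc3cc(-c4ccc(C(F)(F)F)cc4)nn23)cc(OC)c1OC` in this assay gives 1840 nM.
Compound 3 `CCOC(=O)c1ccc(-c2cc3nccc(-c4cc(OC)c(OC)c(OC)c4)n3n2)cc1` in this assay reports only a limit of the assay, > 10000 nM.

Within the data shown here, compound 2 holds the only number in this assay; the other two values are limits. Among the measured compounds shown here, one measured step touches the aryl group on the shared core: an at least 5.4-fold higher number from compound 2 to compound 3 (0.73 log units; beyond the scatter). Two of the three values rest at the limit described by the limit of > 10000 nM in this assay, at which 2 of the 3 values shown sit, so the size of that loss is known only as a lower bound.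

Compound 4 `COc1ccc(-c2cc3nccc(-c4cc(OC)c(OC)c(OC)c4)n3n2)cc1N` differs from compound 2 in the same place: 3-amino-4-methoxyphenyl in place of 4-(trifluoromethyl)phenyl on an aromatic carbon. For the measured compounds named here, the one measured step in that place shows that exchanging trifluoromethyl for ethoxycarbonyl ends measurable activity, but it says nothing about an amino or methoxy group on the entering ring; no measured pair bears directly on 3-amino-4-methoxyphenyl. Going by the values given here, the expectation for compound 4 therefore rests on the single number of compound 2, 1840 nM, with wide uncertainty in both directions. Compound 4 is expected to give 800 nM in this assay, within 100 nM to 6000 nM. That estimate means an expected step of a 2.3-fold lower number from compound 2 to compound 4 (0.36 log units; beyond the scatter), a modest gain, with a real chance that only a limit is reported.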

Compound 4, half-maximal inhibitory concentration: 283 nM
Compound 4: the middle estimate sits 2.8-fold (0.45 log units) above what was measured; the range from low to high includes it.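

In this assay, the aryl position on the shared core now shows movement in both directions: 3-amino-4-methoxyphenyl in place of 4-(trifluoromethyl)phenyl gives a 6.5-fold lower number from compound 2 to compound 4 (0.81 log units; beyond the scatter), so the 4-(trifluoromethyl)phenyl group is not needed for a measurable number here, and the entering ring improves on it. Among these compounds, the only earlier step at this position was a loss, an at least 5.4-fold higher number from compound 2 to compound 3 (0.73 log units; beyond the scatter), which by itself left open whether any change to this ring could do better than compound 2. For compound 3 the value > 10000 nM is a limit of the assay, and the step from it to compound 4 cannot be read: the limit of > 10000 nM in this assay, at which 2 of the 4 values shown sit.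

The amino and methoxy groups enter together in a single step, and the compounds shown do not separate the share of each in the gain. Also open, on these data alone, is where a hydroxyl or an acetamide in place of the amino group would fall, and whether a carboxylic acid or a primary amide in place of the ethoxycarbonyl group would restore a measurable number.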